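Sulfonyl-quinoline series: fluorophenyl position and clearance

The source may report more compounds than this note shows. Statements on the series, on what has been measured and on what is new or still open speak of the compounds shown alone.

Compound 2 `O=S(=O)(c1ccc(F)c(Cl)c1)c1cnc2c(F)cccc2c1-c1ccc(F)cc1` gives 0.19 mL/min in an ADME assay on microsomes from liver (Homo sapiens) for metabolic stability, tested at 2.5 uM; a lower number here means slower removal, a higher number faster removal of the compound. Compound 1 `O=S(=O)(c1ccc(F)c(Cl)c1)c1cnc2c(F)cccc2c1-c1ccccc1F` differs from it by 2-fluorophenyl in place of 4-fluorophenyl on an aromatic carbon and gives 1.39 mL/min in this assay, a 7.3-fold higher number from compound 2 to compound 1 (0.86 log units; beyond the scatter). Compound 3 `O=S(=O)(c1ccc(F)c(F)c1)c1cnc2c(F)cccc2c1-c1ccc(F)cc1` carries a core that differs from compound 2 by fluoro in place of chloro on an aromatic carbon; in this assay compound 3 gives 0.78 mL/min, a 4.1-fold higher number from compound 2 to compound 3 (0.61 log units; beyond the scatter). The values of compound 3 and compound 1 lie within the scatter of each other.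

Compound 4 `O=S(=O)(c1ccc(F)c(F)c1)c1cnc2c(F)cccc2c1-c1ccccc1F` is not yet measured. It differs from compound 3 by 2-fluorophenyl in place of 4-fluorophenyl on an aromatic carbon, the same change that turns compound 2 into compound 1, at a place described in the same words. For compound 4 in this assay a step of a 5.1-fold higher number from compound 3 to compound 4 (0.71 log units; beyond the scatter) is expected, somewhat smaller than the measured one because a 7.3-fold higher number from compound 2 to compound 1 (0.86 log units; beyond the scatter) started from the lower value of compound 2 and compound 3 already stands higher at 0.78 mL/min. Compound 4 is therefore estimated at 4 mL/min, between 1.5 mL/min and 10 mL/min.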

Compound 4, intrinsic clearance in a liver preparation (reported as CLH), per the amount of preparation that the assay uses: 1.39 mL/min
Estimate against measurement, compound 4: 2.9-fold (0.46 log units) above, outside the stated range (below it).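

Going from 4-fluorophenyl to 2-fluorophenyl gives a 1.8-fold higher number from compound 3 to compound 4 (0.25 log units; within the scatter) in this assay, so the size of this change does not carry from one core to the other: the same change on two cores in this assay, a 7.3-fold higher number (0.86 log units; beyond the scatter) from compound 2 to compound 1 and a 1.8-fold higher number (0.25 log units; within the scatter) from compound 3 to compound 4, 4.1-fold (0.61 log units) apart, beyond the scatter of two such steps
Fluoro in place of chloro gives no change at the digits printed from compound 1 to compound 4 (within the scatter) in the same assay, so its size also differs with the group on the shared core: the same change on two cores in this assay, a 4.1-fold higher number (0.61 log units; beyond the scatter) from compound 2 to compound 3 and no change at the digits printed (within the scatter) from compound 1 to compound 4, 4.1-fold (0.61 log units) apart, beyond the scatter of two such steps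
The two changes therefore do not add up across these four compounds, but this rests on a single set of two cores and two changes and shows neither the cause nor the outcome on any other core.

Still open, on these data alone, is whether the same dependence appears with a methoxy group or a nitrile in place of the fluoro or chloro group. As far as these compounds go, an amine in place of the fluorophenyl group is equally open.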